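The compounds below may be only part of what the source reports. "The series", "measured", "known", "first", "only" and "open" are said of these compounds alone.

Compound 2 `Cc1c(Cc2cc(F)ccc2S(=O)(=O)c2ccccc2)c2c(n1CC(=O)O)CCNC2=O` carries a fluoro on its outer aromatic ring and, in a functional assay on CHO.K1 cells for antagonist activity at prostaglandin D2 receptor 2 (Homo sapiens), read by GTPgammaS binding, with a stated time of 1 h (on this read-out lower numbers stand for stronger inhibition and higher numbers for weaker inhibition), compound 2 gives 3.7 nM. Compound 1 `CNC(=O)c1ccc(Cc2c3c(n(CC(=O)O)c2C)CCNC3=O)c(S(=O)(=O)c2ccccc2)c1` differs from it in several places at once and gives 10 nM in this assay, so compound 2 stands as the lower of the two numbers, and the gap between the two lies beyond the usual scatter. Compound 3 `COc1ccc(S(=O)(=O)c2ccccc2)c(Cc2c3c(n(CC(=O)O)c2C)CCNC3=O)c1` has not yet been measured; it carries methoxy in place of fluoro on an aromatic carbon. Among the measured compounds shown here, no measured pair isolates this change, so the step from compound 2 to compound 3 is expected to be small, most likely within the scatter and leaning toward a slightly higher number a 1.4-fold higher number from compound 2 to compound 3 (0.13 log units; within the scatter). Compound 3 is therefore expected to give about 5 nM, between 2 nM and 15 nM.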

Compound 3, half-maximal inhibitory concentration: 3.6 nM
Beside the measured number, compound 3's estimate is 1.4-fold (0.14 log units) above it; the measured number falls inside the stated range.
By their numbers in this assay, from the lowest: compounds 3 and 2 (each within the scatter of the next); then compound 1.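

Within this assay methoxy in place of fluoro on this aromatic carbon, para to a phenylsulfonyl group, gives a 1.0-fold lower number from compound 2 to compound 3 (0.01 log units; within the scatter) and so the two groups cannot be told apart at this position. This single-place pair shows that the read-out holds when methoxy, with its two heavy atoms and one hydrogen-bond acceptor, enters here. Nothing available explains this outcome. From the compounds shown here alone, whether an amine, a carboxylic acid or a longer chain at this position would also stay within the scatter remains open.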